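The source may report more compounds than this note shows. Statements on the series, on what has been measured and on what is new or still open speak of the compounds shown alone.

Compound 2 `COc1ccc(S(=O)(=O)Nc2cc(Cl)cc(Cl)c2)cc1N1CCNCC1` is tested in an assay on isolated protein for binding affinity to 5-hydroxytryptamine receptor 6 (Homo sapiens) (on this read-out lower numbers stand for stronger inhibition and higher numbers for weaker inhibition), where compound 2 gives 0.631 nM. Among the measured compounds shown here, of the two numbers known so far it is the highest, and its nearest neighbour is compound 1 `COc1ccc(S(=O)(=O)Nc2cccc(I)c2)cc1N1CCNCC1`, which in this assay gives 0.501 nM; the step of a 1.3-fold higher number from compound 1 to compound 2 (0.10 log units; within the scatter) lies within the scatter, so nothing separates the two compounds. For the measured compounds named here, the one measured step therefore shows that exchanging halogens on the phenyl carried by the sulfonamide nitrogen left the number essentially unchanged. Compound 3 `COc1ccc(S(=O)(=O)Nc2cc(F)cc(F)c2Cl)cc1N1CCNCC1` carries a further change of this kind: 2-chloro-3,5-difluorophenyl in place of 3,5-dichlorophenyl on a sulfonamide nitrogen. Going by the values given here, the only step that bears on it, from compound 1 to compound 2, was within the scatter, so no movement beyond the scatter is expected in this assay. For compound 3 the account therefore expects 0.7 nM, with a range of 0.3 nM to 1.8 nM, corresponding to the step of a 1.1-fold higher number from compound 2 to compound 3 (0.05 log units; within the scatter).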

Compound 3, inhibition constant: 31.6 nM
The estimate for compound 3 lay 45-fold (1.65 log units) below the measured number, and the stated range ends below it.
By their numbers in this assay, from the lowest: compounds 1 and 2 (each within the scatter of the next); then compound 3.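

In this assay the phenyl on the sulfonamide nitrogen turns out not to be indifferent to every halogen exchange: 2-chloro-3,5-difluorophenyl brings a 50-fold higher number from compound 2 to compound 3 (1.70 log units; beyond the scatter) against 3,5-dichlorophenyl and a 63-fold higher number from compound 1 to compound 3 (1.80 log units; beyond the scatter) against 3-iodophenyl. Compound 1 and compound 2 remain within the scatter of each other, so among these three compounds only compound 3 stands apart, and the earlier step gave no sign that such a change could matter this much. Nothing available here bears on what lies behind this large step.

The compounds shown leave open whether the step follows the chlorine or the two fluorines of the new group, since the two are not separated here. They also leave open how this position would read with a phenyl carrying methoxy or nitrile in place of halogen.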